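Swapping a Dichlorophenoxy Arm for a Fluorophenylthio Arm

A few compounds are considered here, and "the series" means these few. Any claim that something is new, unique, unknown or untested is made for them only; others in the source may bear on it.

Compound 1 `Nc1cc(N)c2nc(-c3ccccc3)c(Oc3ccc(Cl)c(Cl)c3)nc2c1` carries a 3,4-dichlorophenoxy group on the shared core. In a functional assay on UO-31 cells (Homo sapiens) for inhibition, read by sulforhodamine B assay, with a stated time of 48 h (on this read-out higher numbers stand for weaker inhibition of growth and lower numbers for stronger inhibition of growth), compound 1 gives < 100000 nM, which is a limit of the assay rather than a measured number (the limit of < 100000 nM in this assay, at which 1 of the 2 values shown sits). Among the compounds with values here, the only compound with a full number is compound 2 `COc1ccc(CNc2nc3cc(N)cc(N)c3nc2-c2ccccc2)cc1`, which in this assay gives 28800 nM; no step between compound 1 and compound 2 is worked out, so the two readings stand side by side without a stated gap. The unmeasured compound 3 `Nc1cc(N)c2nc(-c3ccccc3)c(Sc3ccc(F)cc3)nc2c1` differs from compound 1 in one place: (4-fluorophenyl)sulfanyl in place of 3,4-dichlorophenoxy on an aromatic carbon. Within the data shown here, no measured pair covers this exchange, so its direction is open; the step from compound 1 to compound 3 is expected to be modest, a step that the limit leaves unreadable from compound 1 to compound 3, with no change beyond the scatter assumed. On that basis compound 3 is expected to give about 35000 nM in this assay, somewhere between 8000 nM and 100000 nM.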

Compound 3, concentration for total growth inhibition: < 100000 nM
Compound 3 gave a limit, no number (the forecaster's own chance of this, stated with the estimate: 35%); the middle value is on the limit's open side.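

Compound 1 and compound 3 both give limits rather than numbers, so no step can be read between them: the limit of < 100000 nM in this assay, at which 2 of the 3 values shown sit. As far as these compounds go, whether (4-fluorophenyl)sulfanyl in place of 3,4-dichlorophenoxy changes growth inhibition at all, and in which direction, stays open.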